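Piperidine substitution on the propoxy chain: antiproliferative readout

This account rests on a few compounds, and the source may have more. Where it says the series, first, only, none or still open, it means among the compounds named here.

Values measured in a functional assay on A549 cells (Homo sapiens) for antiproliferative activity, read by MTT assay, with a stated time of 72 h; a lower number here means a stronger inhibitor, a higher number a weaker inhibitor:
- compound 1 `COc1cc2c(Nc3ccc(C#N)cc3)ncnc2cc1OCCCN1CCCCC1`: 23500 nM
- compound 2 `COc1cc2c(Nc3ccc(C#N)cc3)ncnc2cc1OCCCN1CCCCC1CCO`: reported only as a limit, > 100000 nM
- compound 3 `CCOC(=O)C1CCN(CCCOc2cc3ncnc(Nc4ccc(C#N)cc4)c3cc2OC)CC1`: 89900 nM

Compound 1 holds the lowest number among the measured set; the nearest measured number, that of compound 3, is a step of a 3.8-fold higher number from compound 1 to compound 3 (0.58 log units; beyond the scatter). Compound 2 sits at the limit of the limit of > 100000 nM in this assay, at which 1 of the 3 values shown sits, so its step from compound 1 is known only as an at least 4.2-fold higher number from compound 1 to compound 2 (0.62 log units; beyond the scatter). Between compound 2 and compound 3 the comparison reads an at least 1.1-fold lower number from compound 2 to compound 3 (0.04 log units; that floor lies within the scatter).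

Compound 4 `COc1cc2c(Nc3ccc(C#N)cc3)ncnc2cc1OCCCN1CCC(c2ccccc2)CC1` differs from compound 1 by phenyl in place of hydrogen on a saturated ring carbon. Both measured steps that add a group to the piperidine ring of compound 1 move the number upward: the ethoxycarbonyl step by a 3.8-fold higher number from compound 1 to compound 3 (0.58 log units; beyond the scatter), and the 2-hydroxyethyl step by an at least 4.2-fold higher number from compound 1 to compound 2 (0.62 log units; beyond the scatter). A phenyl on the same saturated ring carbon as the ethoxycarbonyl of compound 3 is therefore expected to give a weaker inhibitor than compound 1, with a step of about the size seen in those two comparisons, and a real chance that this assay returns only a limit.

The expected step from compound 1 is a 2.8-fold higher number from compound 1 to compound 4 (0.44 log units; beyond the scatter). In this assay compound 4 is accordingly estimated at 65000 nM, within a range from 20000 nM to 200000 nM.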

Compound 4, half-maximal inhibitory concentration: 9500 nM
Beside the measured number, compound 4's estimate is 6.8-fold (0.84 log units) above it; measured number outside the range, below it.
By their numbers in this assay, from the lowest: compound 4; then compound 1; then compound 3. At a limit, above all of these: compound 2.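

Within the data shown here, the saturated ring carbon three ring bonds from the ring nitrogen accepts a large group without loss in this assay: phenyl in place of hydrogen gives a 2.5-fold lower number from compound 1 to compound 4 (0.39 log units; beyond the scatter), the only step on the piperidine ring of compound 1 here that lowers the number, while ethoxycarbonyl on the same carbon gives a 3.8-fold higher number from compound 1 to compound 3 (0.58 log units; beyond the scatter). The direction of the step at this carbon therefore depends on the entering group, and exchanging ethoxycarbonyl for phenyl gives a 9.5-fold lower number from compound 3 to compound 4 (0.98 log units; beyond the scatter). Compound 2 is known only as a limit, so its step reads as a floor, an at least 10-fold lower number from compound 2 to compound 4 (1.02 log units; beyond the scatter), and the substituent differs in both group and place: the limit of > 100000 nM in this assay, at which 1 of the 4 values shown sits.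

Going by these compounds, whether the lower number requires an aromatic ring of carbon only remains open, since cyclohexyl, benzyl or pyridyl on the same ring carbon would be needed to separate that from the size of the group. With this assay as the only read-out, the compounds shown also cannot tell what lies behind the step or whether phenyl on another ring carbon would give the same result.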